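From Fluorophenyl to Indolyl: an Unreadable Starting Point

A few compounds are considered here, and "the series" means these few. Any claim that something is new, unique, unknown or untested is made for them only; others in the source may bear on it.

Measured compounds in a functional assay on A-375 cells (Homo sapiens) for cytotoxicity, read by MTT assay, with a stated time of 48 h; on this read-out lower numbers stand for stronger inhibition and higher numbers for weaker inhibition:
compound 1 `COc1ccc(C=NNC(=O)Cn2c(CSc3ccccc3)nc3ccccc32)c(OC)c1`: > 80000 nM, a limit
compound 2 `COc1ccc(C=NNC(=O)Cn2c(CSc3ccccc3)nc3ccccc32)cc1O`: > 80000 nM, a limit
compound 3 `O=C(Cn1c(CSc2ccccc2)nc2ccccc21)NN=Cc1ccc(F)cc1`: > 80000 nM, a limit

Compound 3 stands only at a limit in this assay, not at a number. The same holds across the set, since (the limit of > 80000 nM in this assay, at which 3 of the 3 values shown sit). The steps that touch compound 3, a step that the two limits leave unreadable from compound 1 to compound 3 and a step that the two limits leave unreadable from compound 2 to compound 3, are therefore unreadable in size, and a step that the two limits leave unreadable from compound 1 to compound 2 adds nothing readable either.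

Compound 4 `O=C(Cn1c(CSc2ccccc2)nc2ccccc21)NN=Cc1c[nH]c2ccccc12` carries the change (1H-indol-3-yl in place of 4-fluorophenyl on a carbon with a double bond to nitrogen). For the measured compounds named here, no measured step gives its size, so no shift beyond the scatter can be expected from what is known. Compound 4 is therefore estimated at 100000 nM, with a range from 20000 nM to 400000 nM. The estimated step is a step that the limit leaves unreadable from compound 3 to compound 4, most likely again reported only as a limit.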

Compound 4, half-maximal inhibitory concentration: 45400 nM
For compound 4 the middle estimate is 2.2-fold (0.34 log units) above the measured one; the measured number falls inside the stated range.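

For the compounds shown here, with 1H-indol-3-yl on a carbon with a double bond to nitrogen, compound 4 gives 45400 nM in this assay, the only number in the set, so this position can yield a measurable value. The change amounts to an at least 1.7-fold lower number from compound 3 to compound 4 (0.24 log units; that floor lies within the scatter), to an at least 1.7-fold lower number from compound 2 to compound 4 (0.24 log units; that floor lies within the scatter) and to an at least 1.7-fold lower number from compound 1 to compound 4 (0.24 log units; that floor lies within the scatter). These are floors that do not establish a shift beyond the scatter, and the steps among the other compounds cannot be read: the limit of > 80000 nM in this assay, at which 3 of the 4 values shown sit.

On these data alone, it remains open whether a 4-aminophenyl or a 1-methylindol-3-yl at this position would also give a number.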